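A few compounds are considered here, and "the series" means these few. Any claim that something is new, unique, unknown or untested is made for them only; others in the source may bear on it.

Compound 1 `O[C@@H]1c2cc(OCc3cccc(Cl)n3)ccc2OC[C@@H]1Cc1cccnc1` gives 23400 nM in an assay on membranes from lung for binding affinity to cysteinyl leukotriene receptor 1 (Cavia porcellus); on this read-out higher numbers stand for weaker inhibition and lower numbers for stronger inhibition.
Compound 2 `Cc1nc(COc2ccc3c(c2)[C@@H](O)[C@@H](Cc2cccnc2)CO3)ccc1Br` gives 1560 nM in this assay.

Within the data shown here, of these two numbers, compound 2 stands lowest, and its only neighbour is compound 1, separated by a 15-fold lower number from compound 1 to compound 2 (1.18 log units; beyond the scatter), a step that exchanges one whole pyridyl group for another on the saturated chain carbon bound to an oxygen on the aromatic ring. Compound 3 `Cc1nc(COc2ccc3c(c2)[C@@H](O)[C@@H](Cc2cccnc2)CO3)ccc1[N+](=O)[O-]` differs from compound 2 by nitro in place of bromo on an aromatic carbon. Among the measured compounds shown here, no measured step alters this position on its own: the single step available, a 15-fold lower number from compound 1 to compound 2 (1.18 log units; beyond the scatter), replaces the entire pyridyl group, so it bears only loosely on the bromo-to-nitro exchange. Compound 3 is therefore expected to show a 1.3-fold higher number from compound 2 to compound 3 (0.11 log units; within the scatter), a step that need not exceed the scatter. Compound 3 is estimated at 2000 nM in this assay, with a range from 500 nM to 8000 nM.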

Compound 3, inhibition constant: 240 nM
For compound 3 the middle estimate is 8.3-fold (0.92 log units) above the measured one; measured number outside the range, below it.
By their numbers in this assay, from the lowest: compound 3; then compound 2; then compound 1.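

The bromo-to-nitro exchange, ortho to the methyl group, shows that this aromatic carbon matters on its own in this assay: the step is a 6.5-fold lower number from compound 2 to compound 3 (0.81 log units; beyond the scatter), whereas the earlier step changed the whole pyridyl group. Carried through from the chloropyridyl end of the series, the replacement of 6-chloropyridin-2-yl by 6-methyl-5-nitropyridin-2-yl amounts to a 98-fold lower number from compound 1 to compound 3 (1.99 log units; beyond the scatter), so the single exchange of bromo for nitro adds clearly to what the earlier step had shown. No measured property is available to explain this step.

The compounds shown leave open how an amine, a nitrile or a carboxylic acid on this aromatic carbon would read. They also leave open what part the methyl group plays, as compound 2 and compound 3 both carry it.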